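The compounds below may be only part of what the source reports. "The series", "measured", "known", "first", "only" and "open" are said of these compounds alone.

Three compounds share one core and differ only in a single substituent. Compound 1 `CCCS(=O)(=O)Nc1ccc(F)c(C(=O)c2n[nH]c3ncc(-c4ccccc4OC)cc23)c1F` gives 1.9% in an assay for binding affinity to dual specificity mitogen-activated protein kinase kinase 4 (Homo sapiens), read by KINOMEscan, tested at 100 nM; on this read-out higher numbers stand for a weaker effect at the one concentration tested and lower numbers for a stronger effect. Compound 2 `CCCS(=O)(=O)Nc1ccc(F)c(C(=O)c2n[nH]c3ncc(-c4ccc(OC)cc4)cc23)c1F` gives 4.2%, and compound 3 `CCCS(=O)(=O)Nc1ccc(F)c(C(=O)c2n[nH]c3ncc(-c4ccccc4O)cc23)c1F` gives 9%. Compound 3 carries the highest of the three numbers, yet both gaps, a number 7.1 percentage points higher from compound 1 to compound 3 (within the scatter) and a number 4.8 percentage points higher from compound 2 to compound 3 (within the scatter), fall inside the scatter, so the three cannot be told apart. Compound 4 `CCCS(=O)(=O)Nc1ccc(F)c(C(=O)c2n[nH]c3ncc(-c4ccc(N)cc4)cc23)c1F` has not yet been measured; it carries 4-aminophenyl in place of 2-hydroxyphenyl on an aromatic carbon. The measured steps that bear on this, a number 4.8 percentage points higher from compound 2 to compound 3 (within the scatter) and a number 2.3 percentage points higher from compound 1 to compound 2 (within the scatter), both lie within the scatter. A step of a number 4 percentage points lower from compound 3 to compound 4 (within the scatter) is therefore expected, with no shift beyond the scatter. Compound 4 is estimated at 5%, between 1% and 15%.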

Compound 4, a percentage reported as activity, at one concentration (the size of the read-out at that concentration, not a potency): 0.1%
Compound 4: the middle estimate sits 4.9 percentage points above what was measured; measured number below the stated range.
By their numbers in this assay, from the lowest: compounds 4, 1, 2 and 3 (each within the scatter of the next).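

In this assay the 4-aminophenyl group of compound 4 stays within the scatter of all three earlier groups: the 2-hydroxyphenyl (a number 8.9 percentage points lower from compound 3 to compound 4 (within the scatter)), the 4-methoxyphenyl (a number 4.1 percentage points lower from compound 2 to compound 4 (within the scatter)) and the 2-methoxyphenyl (a number 1.8 percentage points lower from compound 1 to compound 4 (within the scatter)). This position has now taken a nitrogen-bearing group as well as oxygen-bearing ones, with no shift beyond the scatter. No evidence is available to explain these readings. Still open, on these data alone, is whether a carboxylic acid on the phenyl ring, or a morpholine ring in its place, would move the number beyond the scatter.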